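N-Ethyl Extension on a Piperidine Ketal Scaffold

A few compounds are considered here, and "the series" means these few. Any claim that something is new, unique, unknown or untested is made for them only; others in the source may bear on it.

Compounds measured so far:
compound 1, `c1ccc([C@H]2OC[C@H]([C@@H]3CCCCN3)O2)cc1`: in a functional assay (brain) for displacement of a labelled ligand, with Rattus norvegicus as the target (a lower number here means a stronger inhibitor, a higher number a weaker inhibitor), compound 1 gives 25000 nM
compound 2, `CCCCCCCCC[C@]1(c2ccccc2)OC[C@H]([C@@H]2CCCCN2)O1`: in this assay compound 2 gives 43000 nM
compound 3, `CN1CCCC[C@H]1[C@H]1COC(c2ccccc2)(c2ccccc2)O1`: in this assay compound 3 gives 4400 nM

Compound 3 has the lowest number of the three, and so is the strongest inhibitor in this set. Compound 1 is its nearest neighbour and compound 2 its furthest, and both gaps lie beyond the usual scatter of this kind of measurement. Among the compounds with values here, no two of the three differ in just one place, so no single step between measured compounds can be read off.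

Compound 4, `CCCN1CCCC[C@H]1[C@H]1COC(c2ccccc2)(c2ccccc2)O1`, is the next compound. It differs from compound 3 in one way: ethyl in place of hydrogen on a saturated chain carbon bound to an amine nitrogen in a ring. The change is small and sits on the chain carbon bound to the ring amine nitrogen; cut one bond further out, it reads as methyl to propyl.

Nothing in the measured set shows how extending this chain shifts the number, so the expectation rests on compound 3 alone. Compound 4 is expected to stay close to compound 3, with a step of a 1.3-fold lower number from compound 3 to compound 4 (0.10 log units; within the scatter) that may not exceed the scatter. Compound 4 is estimated at 3500 nM, within a range from 800 nM to 15000 nM.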

Compound 4, inhibition constant: 6800 nM
Compound 4: middle estimate off by 1.9-fold (0.29 log units), on the low side; measured number inside the range.
By their numbers in this assay, from the lowest: compounds 3 and 4 (each within the scatter of the next); then compounds 1 and 2 (each within the scatter of the next).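

Within the data shown here, this is the first comparison in the set between two compounds that differ in one place only, so the effect of a single change can now be read directly. In this assay, ethyl in place of hydrogen on a saturated chain carbon bound to an amine nitrogen in a ring, which cut one bond further out reads as methyl to propyl, gives a 1.5-fold higher number from compound 3 to compound 4 (0.19 log units; within the scatter); compound 3 and compound 4 therefore cannot be told apart, and at this position the change from methyl to propyl leaves no effect that can be separated from ordinary measurement noise. Nothing available offers an explanation for this result.

As far as these compounds go, a single step at one chain length shows no trend, so it remains open whether a longer chain such as hexyl, or a benzyl group, at this same place would also leave the number within the scatter of compound 3. From the compounds shown here alone, it also remains open whether the same ethyl change would read the same way on a different core, such as the core of compound 1.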